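Fluoro on the benzothiazole: cytotoxicity

This account rests on a few compounds, and the source may have more. Where it says the series, first, only, none or still open, it means among the compounds named here.

Compound 1: `Cc1ccc(-c2ccc(C)n2-c2ccc(-c3nc4ccccc4s3)cc2)cc1`, 30600 nM
Compound 2: `COc1cc(-c2ccc(C)n2-c2ccc(-c3nc4ccccc4s3)cc2)cc(OC)c1OC`, 38800 nM
Compound 3: `Cc1ccc(-c2ccc(C)n2-c2ccc(-c3nc4ccc(F)cc4s3)cc2)cc1`, 33600 nM

Of the compounds shown here, three have been measured in an ADME assay on MCF-10A cells (Homo sapiens) for cytotoxicity, read by MTT assay, with a stated time of 72 h; a higher number here means a weaker inhibitor, a lower number a stronger inhibitor. Compound 1 gives 30600 nM, compound 2 gives 38800 nM and compound 3 gives 33600 nM; all three numbers lie within the usual scatter of one another. Compound 3 differs from compound 1 by fluoro in place of hydrogen on an aromatic carbon, and that step is a 1.1-fold higher number from compound 1 to compound 3 (0.04 log units; within the scatter). The difference between the core of compound 1 and the core of compound 2 is not broken down here.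

Compound 4, `COc1cc(-c2ccc(C)n2-c2ccc(-c3nc4ccc(F)cc4s3)cc2)cc(OC)c1OC`, is not yet measured. It differs from compound 2 by fluoro in place of hydrogen on an aromatic carbon, the same change that led from compound 1 to compound 3. Because that earlier step was a 1.1-fold higher number from compound 1 to compound 3 (0.04 log units; within the scatter), the step in this assay is expected to be small, a 1.1-fold higher number from compound 2 to compound 4 (0.03 log units; within the scatter). Compound 4 is therefore estimated at 42000 nM, expected between 20000 nM and 85000 nM.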

Compound 4, half-maximal inhibitory concentration: 40000 nM
Compound 4: the middle estimate sits 1.1-fold (0.02 log units) above what was measured, and the stated range covers the measured number.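

Replacing 1,3-benzothiazol-2-yl with 6-fluoro-1,3-benzothiazol-2-yl on the core of compound 2 gives a 1.0-fold higher number from compound 2 to compound 4 (0.01 log units; within the scatter) in this assay. Set beside the earlier step, the same change reads alike on the two cores: the same change on two cores in this assay, a 1.1-fold higher number (0.04 log units; within the scatter) from compound 1 to compound 3 and a 1.0-fold higher number (0.01 log units; within the scatter) from compound 2 to compound 4, 1.1-fold (0.03 log units) apart, within the scatter of two such steps. This shows agreement only for these two cores in this one assay; neither step lies beyond the scatter, so it does not show that a step of real size would carry over, or that the change would read alike on a third core.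

The compounds shown leave open how a different group at this place on the benzothiazole, such as an amine or a carboxylic acid, would read in this assay.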